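Extending the amide chain on the weakest of three analogues

The compounds below may be only part of what the source reports. "The series", "measured", "known", "first", "only" and "open" are said of these compounds alone.

Compound 1 `CNC(=O)c1cc(Oc2ccc(NC(=O)c3cc4cccnc4n(-c4ccccc4F)c3=O)cc2)ccn1` in a functional assay on HT-29 cells (Homo sapiens) for antiproliferative activity, read by MTT assay, with a stated time of 72 h (on this read-out lower numbers stand for stronger inhibition and higher numbers for weaker inhibition), gives 260 nM.
Compound 2 `CNC(=O)c1cc(Oc2ccc(NC(=O)c3cc4cccnc4n(-c4ccc(F)cc4)c3=O)cc2)ccn1` in this assay gives 160 nM.
Compound 3 `CNC(=O)c1cc(Oc2ccc(NC(=O)c3cc4cccnc4n(-c4ccc(Br)cc4)c3=O)cc2)ccn1` in this assay gives 1180 nM.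

Compound 3 has the highest number of the three, the weakest inhibitor here: a 4.5-fold higher number from compound 1 to compound 3 (0.66 log units; beyond the scatter) and a 7.4-fold higher number from compound 2 to compound 3 (0.87 log units; beyond the scatter), both beyond the scatter, while a 1.6-fold lower number from compound 1 to compound 2 (0.21 log units; within the scatter) stays within it. Compound 4 `CCCNC(=O)c1cc(Oc2ccc(NC(=O)c3cc4cccnc4n(-c4ccc(Br)cc4)c3=O)cc2)ccn1` keeps the whole of compound 3 and changes only the methylcarbamoyl end: ethyl in place of hydrogen on a saturated chain carbon bound to an amide-type nitrogen. For the measured compounds named here, none of the measured steps touches this part of the molecule; all three concern the aryl group on the aromatic nitrogen. No basis therefore exists for expecting a shift beyond the scatter in this assay, and compound 4 is estimated at 1200 nM (range 500 nM to 3000 nM), meaning an expected step of a 1.0-fold higher number from compound 3 to compound 4 (0.01 log units; within the scatter).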

Compound 4, half-maximal inhibitory concentration: 530 nM
Compound 4: middle estimate off by 2.3-fold (0.35 log units), on the high side, within the range that was stated.
By their numbers in this assay, from the lowest: compounds 2 and 1 (each within the scatter of the next); then compound 4; then compound 3.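

For the compounds shown here, the methylcarbamoyl end, which no earlier step touched, does respond in this assay: propylcarbamoyl in its place gives a 2.2-fold lower number from compound 3 to compound 4 (0.35 log units; beyond the scatter) and so moves the number modestly, just beyond the scatter. This shows that the end of the molecule far from the 4-bromophenyl group can also shift the read-out. No measurement available here accounts for the step.

Still open, going by these compounds, is whether a longer chain such as butyl, or a chain ending in an amine, would move the number further, and whether the same change would hold with a 4-fluorophenyl or 2-fluorophenyl group.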